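A few compounds are considered here, and "the series" means these few. Any claim that something is new, unique, unknown or untested is made for them only; others in the source may bear on it.

Compound 1 `O=C(O)CCCCCCC(=O)Nc1ccc(C2=C(c3ccc(O)cc3)C3CC(S(=O)(=O)Oc4ccccc4C(F)(F)F)C2O3)cc1`: > 100000 nM
Compound 2 `O=S(=O)(Oc1ccccc1)[C@H]1C[C@H]2O[C@@H]1C(c1ccc(O)cc1)=C2c1ccc(O)cc1`: > 100000 nM

Both compounds were tested in a functional assay on DU-145 cells (Homo sapiens) for inhibition, read by MTT assay, with a stated time of 72 h; a higher number here means a weaker inhibitor, a lower number a stronger inhibitor. In this assay, compound 1 gives > 100000 nM, which is a limit of the assay and not a number. Compound 2 gives > 100000 nM, which is also a limit. Compound 1 therefore stands with every result so far: the limit of > 100000 nM in this assay, at which 2 of the 2 values shown sit. For the measured compounds named here, neither compound has a true half-maximal inhibitory concentration, and no measured step is available as a guide.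

Compound 3 `O=C(O)CCCCCCC(=O)Nc1ccc(C2=C(c3ccc(O)cc3)C3CC(S(=O)(=O)Oc4cccc5ccccc45)C2O3)cc1` keeps the rest of compound 1 and changes one group, with naphthalen-1-yl in place of 2-(trifluoromethyl)phenyl on an oxygen whose other neighbour is the sulfonyl sulfur: naphthalen-1-yl in place of 2-(trifluoromethyl)phenyl on an oxygen. The only anchor for an expectation is compound 1 at its limit of > 100000 nM. In this assay, no step beyond the usual scatter is expected, so the expected change is a number no higher from compound 1 to compound 3 (the limit leaves the size open). The assay may well report only a limit again. For compound 3, the estimated value is 100000 nM, with an expected range from 30000 nM to 200000 nM.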

Compound 3, half-maximal inhibitory concentration: 48600 nM
For compound 3 the middle estimate is 2.1-fold (0.31 log units) above the measured one; the measured number falls inside the stated range.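

This is the only true half-maximal inhibitory concentration among the compounds shown, and it shows that the group on an oxygen whose other neighbour is the sulfonyl sulfur can change the read-out: in this assay, naphthalen-1-yl in place of 2-(trifluoromethyl)phenyl gives an at least 2.0-fold lower number from compound 1 to compound 3 (0.31 log units; beyond the scatter). The two groups have the same number of heavy atoms, and neither has hydrogen-bond donors, hydrogen-bond acceptors or a net charge, so the counted differences are the second six-membered aromatic ring and the loss of the fluorine atoms. Compound 1 has only a limit of the assay and not a number, so the true size of this step stays unknown, and limits still make up most of the results: the limit of > 100000 nM in this assay, at which 2 of the 3 values shown sit.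

The compounds shown leave open whether the step belongs to the added ring or to the loss of the trifluoromethyl group, a question that a plain phenyl or a naphthalen-2-yl on the same oxygen, with the rest of compound 1 unchanged, could help to separate. They also leave open whether the step would hold with a primary amide in place of the carboxylic acid, or with a shorter chain.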